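Alkoxy chain lengthening on the chalcone series

The compounds below may be only part of what the source reports. "The series", "measured", "known", "first", "only" and "open" are said of these compounds alone.

Measured so far:
compound 1 `Cc1ccc(C(=O)/C=C/c2ccc(O)c(O)c2)cc1` — 76 nM in an assay on RBL-1 cells for inhibition of Polyunsaturated fatty acid 5-lipoxygenase (Rattus norvegicus); on this read-out lower numbers stand for stronger inhibition and higher numbers for weaker inhibition
compound 2 `COc1ccc(C(=O)/C=C/c2ccc(O)c(O)c2)cc1` — 20 nM in this assay

Compound 2 holds the lowest of the two numbers in this assay; its nearest neighbour is compound 1, and the change from compound 1 to compound 2 gave a 3.8-fold lower number from compound 1 to compound 2 (0.58 log units; beyond the scatter).

Compound 3 `CC(C)Oc1ccc(C(=O)/C=C/c2ccc(O)c(O)c2)cc1` is not yet measured. It differs from compound 2 in one place: isopropyl in place of methyl on an oxygen on an aromatic ring.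

For the measured compounds named here, only the step from compound 1 to compound 2 bears on this, and only loosely: it swapped methyl for methoxy on the aromatic carbon, whereas the new change enlarges the alkyl on the ether oxygen itself. Going by the values given here, no measured pair varies the size of that alkyl, so there is no direct guide. The expectation for compound 3 is a step of a 1.3-fold higher number from compound 2 to compound 3 (0.10 log units; within the scatter), probably within the scatter. Compound 3 is therefore estimated at 25 nM in this assay, with a range from 8 nM to 80 nM.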

Compound 3, half-maximal inhibitory concentration: 41 nM
The estimate for compound 3 lay 1.6-fold (0.21 log units) below the measured number; low and high end bracket the measured number.
By their numbers in this assay, from the lowest: compound 2; then compounds 3 and 1 (each within the scatter of the next).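

Going from methoxy to isopropoxy gave a 2.1-fold higher number from compound 2 to compound 3 (0.31 log units; beyond the scatter) in this assay, which shows that the size of the alkyl on this oxygen registers in the read-out, though only modestly. Isopropoxy in place of methyl gave a 1.9-fold lower number from compound 1 to compound 3 (0.27 log units; within the scatter) and so does not clearly separate the two, which means the gain seen with methoxy, a 3.8-fold lower number from compound 1 to compound 2 (0.58 log units; beyond the scatter) on the same read-out, does not plainly carry over to the larger ether. Nothing measured here speaks to why the larger alkyl behaves this way.

With only methoxy and isopropoxy on this oxygen, the effects of branching and chain length cannot be told apart, and ethoxy or a straight propoxy chain would address that. Also open, going by these compounds, is how a longer chain ending in an amine or a carboxylic acid would read here.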